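Will compound 4 lose its cytotoxicity as well?

The compounds below may be only part of what the source reports. "The series", "measured", "known", "first", "only" and "open" are said of these compounds alone.

Within the data shown here, in a functional assay on A549 cells (Homo sapiens) for cytotoxicity, read by MTT assay, with a stated time of 48 h (on this read-out higher numbers stand for weaker inhibition and lower numbers for stronger inhibition), compound 1 `Cc1cccc(Cn2cc(COc3ccc4c(=O)ccoc4c3)nn2)c1` gives 20300 nM as the only true number among the measured compounds. Compound 2 `O=c1ccoc2cc(OCc3cn(Cc4ccc(Cl)cc4)nn3)ccc12` stands at > 100000 nM which is a limit of the assay. Compound 3 `O=c1ccoc2cc(OCc3cn(Cc4cccc(F)c4)nn3)ccc12` gives > 100000 nM which is again a limit. Compound 4 `O=c1ccoc2cc(OCc3cn(Cc4ccc(F)cc4)nn3)ccc12` is not yet measured and differs from compound 1 by 4-fluorophenyl in place of 3-methylphenyl on a saturated chain carbon bound to an aromatic nitrogen so that 3-methylbenzyl becomes 4-fluorobenzyl. Among the measured compounds shown here, two measured steps bear on this: 4-chlorophenyl in place of 3-methylphenyl gave an at least 4.9-fold higher number from compound 1 to compound 2 (0.69 log units; beyond the scatter) and fluoro in place of methyl gave an at least 4.9-fold higher number from compound 1 to compound 3 (0.69 log units; beyond the scatter) and both lie beyond the scatter toward weaker inhibition. In this assay a rise of similar size is therefore expected as a 4.9-fold higher number from compound 1 to compound 4 (0.69 log units; beyond the scatter) toward weaker inhibition. The estimate for compound 4 is 100000 nM with an expected range from 40000 nM to 250000 nM and a limit of the assay is quite possible.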

Compound 4, half-maximal inhibitory concentration: > 100000 nM
Compound 4 was reported as a limit; the forecaster's own chance of this, stated with the estimate: 70%; the middle value sits exactly at the limit.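

With 4-fluorophenyl in place of 3-methylphenyl, the result is an at least 4.9-fold higher number from compound 1 to compound 4 (0.69 log units; beyond the scatter). Fluoro in the 4-fluorophenyl group thus ends like fluoro in the 3-fluorophenyl group of compound 3 and chloro in the 4-chlorophenyl group of compound 2, leaving compound 1 the only one with a true number. The steps among compounds 2, 3 and 4 cannot be read, since each value is a limit: the limit of > 100000 nM in this assay, at which 3 of the 4 values shown sit.

Still open, on these data alone, is whether the methyl group itself matters or its place on the ring. A 4-methylphenyl group, or a phenyl ring carrying an amine, could separate the two.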